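The source may report more compounds than this note shows. Statements on the series, on what has been measured and on what is new or still open speak of the compounds shown alone.

Compound 1 `O=C(O)c1cnc2ccc(C3CCCCC3)cc2c1` was tested in a functional assay on the whole organism (strain Sprague-Dawley) for inhibition, with Rattus norvegicus as the target; a lower number here means that less compound is needed, a higher number that more compound is needed for the effect. In this assay compound 1 gives only a limit, > 25 mg/kg, and not a number. Compound 1 thus sits at the limit of > 25 mg/kg in this assay, at which 1 of the 2 values shown sits. For the measured compounds named here, compound 2 `CCc1cccc2c(=O)c(-c3nn[nH]n3)c[nH]c12` is the one compound with a plain number: in this assay compound 2 gives 0.312 mg/kg, so compound 2 stands alone as the sole plain number among the values shown. Compound 3 `O=c1c(-c2nn[nH]n2)c[nH]c2c(C(F)(F)F)cccc12` has not yet been measured. Compound 3 differs from compound 2 in one place: trifluoromethyl in place of ethyl on an aromatic carbon. Going by the values given here, no pair of measured compounds differing in one place has been reported, so the size of such a step cannot be read from measured pairs. The step is expected to stay within the usual scatter or to cost a little, so compound 3 is expected to show a shift of a 1.6-fold higher number from compound 2 to compound 3 (0.20 log units; within the scatter) in this assay. Compound 3 is accordingly estimated at 0.5 mg/kg in this assay, with a range from 0.15 mg/kg to 2 mg/kg.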

Compound 3, minimum effective dose: 0.156 mg/kg
The estimate for compound 3 lay 3.2-fold (0.51 log units) above the measured number; the range from low to high includes it.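

For the compounds shown here, the exchange of ethyl for trifluoromethyl on an aromatic carbon, ortho to a fused ring, gives the first step that can be read here: a 2.0-fold lower number from compound 2 to compound 3 (0.30 log units; within the scatter) in this assay for this pair. This place thus carries either group, one of 2 heavy atoms and the other of 4 heavy atoms, without a difference that stands out from the usual scatter of the whole-organism read-out. Nothing given here bears on the reason for this step.

From the compounds shown here alone, what an amine, a chlorine atom or a longer chain would give on this same aromatic carbon stays open. Going by these compounds, with a single step to go on, it also stays open whether the same exchange would behave alike on another carbon of this ring.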